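Two Close Neighbours and an Untested Methyl Analogue

The source may hold more compounds than are shown below. What is called first, only, known or untested is meant among the compounds shown, and "the series" means these compounds.

Values in a functional assay on MCF7 cells (Homo sapiens) for inhibition, read by MTT assay, with a stated time of 72 h (on this read-out higher numbers stand for weaker inhibition and lower numbers for stronger inhibition), so far

- Compound 1 `COc1cc2c(Oc3ccc(NC(=O)c4nn(-c5ccccc5C)cc(C)c4=O)c(F)c3)ccnc2cc1OCCCCCCC(=O)NO` gives 2690 nM
- Compound 2 `COc1cc2c(Oc3ccc(NC(=O)c4nn(-c5ccc(F)c(Cl)c5)cc(C)c4=O)cc3)ccnc2cc1OCCCCCCC(=O)NO` gives 2200 nM

Compound 2, at 2200 nM, stands level with compound 1, at 2690 nM, since the two values lie within the usual scatter of each other. Compound 3 `COc1cc2c(Oc3ccc(NC(=O)c4nn(-c5ccc(C)cc5)cc(C)c4=O)cc3)ccnc2cc1OCCCCCCC(=O)NO` has not yet been measured. It carries 4-methylphenyl in place of the 3-chloro-4-fluorophenyl of compound 2 on an aromatic nitrogen (4-methylphenyl in place of 3-chloro-4-fluorophenyl on an aromatic nitrogen). Going by the values given here, no measured pair differs in one place only, so the data show no direct effect of this change. Among the compounds with values here, the only guide is the closeness of the two measured values, so no shift beyond the scatter is expected. In this assay the expected step is a 1.1-fold higher number from compound 2 to compound 3 (0.06 log units; within the scatter), a slight weakening at most. The estimate for compound 3 is 2500 nM, with an expected range from 1000 nM to 6000 nM.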

Compound 3, half-maximal inhibitory concentration: 2560 nM
Beside the measured number, compound 3's estimate is 1.0-fold (0.01 log units) below it, within the range that was stated.
By their numbers in this assay, from the lowest: compounds 2, 3 and 1 (each within the scatter of the next).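

Going by these compounds alone, this is the first pair that differs in one place only, so the group on the aromatic nitrogen can now be judged directly. In this assay, putting 4-methylphenyl in place of 3-chloro-4-fluorophenyl gives a 1.2-fold higher number from compound 2 to compound 3 (0.07 log units; within the scatter) and so does not separate the two groups. At this position, a ring carrying chlorine and fluorine and a ring carrying only a methyl group therefore read alike, and no other data here bear on why.

Going by these compounds, whether this tolerance extends to other kinds of group on the same nitrogen, such as a pyridine ring or a phenyl ring bearing a carboxylic acid or an amine, remains open. Also open, on these data alone, is whether the two groups would still read alike with a shorter or longer chain on the core.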